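From ethoxymethyl to isopropoxymethyl on a shared core

The compounds below may be only part of what the source reports. "The series", "measured", "known", "first", "only" and "open" are said of these compounds alone.

- Compound 1 `COCc1cc(CN2CCCCC2)c(O)c2ncccc12`: 9550 nM
- Compound 2 `CCOCc1cc(CN2CCCCC2)c(O)c2ncccc12`: 9120 nM

In a functional assay on MES-SA cells (Homo sapiens) for inhibition, with a stated time of 72 h, in the presence of a further agent that is not named here (on this read-out lower numbers stand for stronger inhibition and higher numbers for weaker inhibition), compound 2 gives 9120 nM, which cannot be told apart from the value of compound 1. Compound 3 `CC(C)OCc1cc(CN2CCCCC2)c(O)c2ncccc12` is still unmeasured. Its change is methyl in place of hydrogen on a saturated chain carbon bound to an oxygen on a saturated carbon and a saturated chain carbon, turning ethoxymethyl into isopropoxymethyl. Going by the values given here, the one measured step that bears on this is a 1.0-fold lower number from compound 1 to compound 2 (0.02 log units; within the scatter), also methyl in place of hydrogen, and it stayed within the scatter. No step beyond the scatter is therefore expected in this assay, in either direction. The expected step is a 1.1-fold lower number from compound 2 to compound 3 (0.03 log units; within the scatter). The estimated value for compound 3 is 8500 nM, with a range of 4000 nM to 17000 nM.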

Compound 3, half-maximal inhibitory concentration: 5750 nM
Compound 3: the middle estimate sits 1.5-fold (0.17 log units) above what was measured, within the range that was stated.
By their numbers in this assay, from the lowest: compounds 3, 2 and 1 (each within the scatter of the next).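

In this assay, methyl in place of hydrogen on the saturated chain carbon gives a 1.6-fold lower number from compound 2 to compound 3 (0.20 log units; within the scatter) and, taken together with the previous methyl, isopropyl in place of methyl on the oxygen gives a 1.7-fold lower number from compound 1 to compound 3 (0.22 log units; within the scatter) across the series. So a second added methyl at this place stays within the scatter just as the first did, and the three compounds cannot be told apart by this read-out. Nothing available here explains these numbers. The compounds shown leave open whether a longer chain such as butyl, a tert-butyl group or an amine on this chain would give a step beyond the scatter.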